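The compounds below may be only part of what the source reports. "The series", "measured", "known", "first", "only" and "open" are said of these compounds alone.

Measured so far:
compound 1, `CCC(CC)=NNc1nc(-c2cccc([N+](=O)[O-])c2)cs1`: 24300 nM
compound 2, `CCCC/C(C)=N\Nc1nc(-c2cccc([N+](=O)[O-])c2)cs1`: 6330 nM

In an assay on isolated protein for inhibition of Amine oxidase [flavin-containing] A (Homo sapiens), read by fluorescence, with a stated time of 20 min (a lower number here means a stronger inhibitor, a higher number a weaker inhibitor), compound 2 stands as the lower of the two measured numbers. Among the measured compounds shown here, the only measured step is a 3.8-fold lower number from compound 1 to compound 2 (0.58 log units; beyond the scatter), which came with a chain of one more heavy atom on the nitrogen on the aromatic ring. Compound 3, `CCC/C(CC)=N\Nc1nc(-c2cccc([N+](=O)[O-])c2)cs1`, is the next compound to be read in this assay. It differs from compound 2 in that (a group of 7 heavy atoms (6 carbon, 1 nitrogen; no ring) in place of a group of 7 heavy atoms (6 carbon, 1 nitrogen; no ring), on a nitrogen on an aromatic ring); the two have the same atoms, joined differently. For the measured compounds named here, the one measured step does bear on the change, since the group in compound 3 has the same number of heavy atoms as that in compound 2 and resembles the group in compound 1 in the way the chain branches at the double bond. Going by the values given here, no measured step tells what such a rearrangement does at equal size. The estimate for compound 3 in this assay is therefore placed between the two measured values, at 11000 nM with a range from 4000 nM to 30000 nM, a step of a 1.7-fold higher number from compound 2 to compound 3 (0.24 log units; within the scatter) that may or may not pass the scatter.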

Compound 3, half-maximal inhibitory concentration: 4860 nM
For compound 3 the middle estimate is 2.3-fold (0.35 log units) above the measured one, and the stated range covers the measured number.
By their numbers in this assay, from the lowest: compounds 3 and 2 (each within the scatter of the next); then compound 1.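

In this assay the same atoms joined differently in the group on a nitrogen on an aromatic ring give a 1.3-fold lower number from compound 2 to compound 3 (0.11 log units; within the scatter) and so leave compound 2 and compound 3 inseparable at this position. The added methyl gives a 5.0-fold lower number from compound 1 to compound 3 (0.70 log units; beyond the scatter) and thus provides a second step beyond the scatter from compound 1, now to a group with a different arrangement from that in compound 2. Among these three compounds, the two carrying the group of 7 heavy atoms both stand apart from compound 1 while their own values do not separate, but no supporting evidence is available to explain this.

The compounds shown leave open whether a longer chain, such as a hexyl group, or a cyclohexyl ring closed through the carbon with the double bond to nitrogen would lower the number further. From the compounds shown here alone, they also leave open how the number would respond to an amine or a carboxylic acid at the end of the chain, so the reach of this trend beyond simple carbon chains remains unknown.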